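Anilino series: removing the methoxy from compound 1

A few compounds are considered here, and "the series" means these few. Any claim that something is new, unique, unknown or untested is made for them only; others in the source may bear on it.

compound 1 `COc1ccc(NC2=CC(=O)c3c(nc4n3[C@H]3OC[C@@H](O)[C@H]3OC4)C2=O)cc1` — 3410 nM
compound 2 `COc1cccc(NC2=CC(=O)c3nc4n(c3C2=O)[C@H]2OC[C@@H](O)[C@H]2OC4)c1` — 7620 nM

Both numbers come from a functional assay on ECa-109 cells for inhibition, with ECa-109 cell line (Homo sapiens) as the target, read by sulforhodamine B assay; on this read-out lower numbers stand for stronger inhibition and higher numbers for weaker inhibition. Compound 1 stands at the lower of the two; compound 2 lies beyond the scatter above it. For the measured compounds named here, no pair of measured compounds differs in one place, so nothing measured here tracks a single change. Compound 3 `O=C1C(Nc2ccccc2)=CC(=O)c2c1nc1n2[C@H]2OC[C@@H](O)[C@H]2OC1` differs from compound 1 in one place: hydrogen in place of methoxy on an aromatic carbon. Going by the values given here, with no measured step of this kind to lean on, the expected step is a 1.3-fold higher number from compound 1 to compound 3 (0.12 log units; within the scatter), none beyond the scatter. Compound 3 is expected to give 4500 nM in this assay, in the range 1800 nM to 11000 nM.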

Compound 3, half-maximal inhibitory concentration: 3560 nM
Compound 3: middle estimate off by 1.3-fold (0.10 log units), on the high side; the range from low to high includes it.
By their numbers in this assay, from the lowest: compounds 1 and 3 (each within the scatter of the next); then compound 2.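

Hydrogen in place of methoxy on the aromatic carbon para to a large group gives a 1.0-fold higher number from compound 1 to compound 3 (0.02 log units; within the scatter) in this assay. The methoxy is therefore not needed at this place to hold the number, and 4-methoxyphenyl and phenyl read alike here. Nothing on hand bears on why this change leaves the number within the scatter.

Still open, on these data alone, is whether an amine, a carboxylic acid or a longer chain at this place would move the number. Also open, as far as these compounds go, is whether the same change reads alike on another core.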